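Cyanobenzyl for Aminobenzyl: Cytotoxicity Expectation

The source may report more compounds than this note shows. Statements on the series, on what has been measured and on what is new or still open speak of the compounds shown alone.

Compound 1, `COC(=O)c1ccc(NCc2cncn2Cc2ccc(N)cc2)cc1-c1ccccc1`, in a toxicity assay on NIH3T3 cells (Mus musculus) for cytotoxicity, read by resazurin assay (a higher number here means that more compound is needed for the effect, a lower number that less compound is needed), gives only the assay limit > 10000 nM.
Compound 2, `Cc1ccccc1-c1cccc(NCc2cncn2Cc2ccccc2)c1`, in this assay gives only the limit > 1000 nM.
Compound 3, `Cc1ccccc1-c1cc(NCc2cncn2Cc2ccc(-c3ccccc3)cc2)ccc1-c1nc2ccccc2s1`, in this assay gives only the limit > 1000 nM.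

None of the three values is a number; each is a limit of the assay. Compound 1 sits at the limit of > 10000 nM in this assay, at which 1 of the 3 values shown sits, while the other two sit at the limit of > 1000 nM in this assay, at which 2 of the 3 values shown sit. Within the data shown here, no step between measured compounds can be read from such limits.

Compound 4, `COC(=O)c1ccc(NCc2cncn2Cc2cccc(C#N)c2)cc1-c1ccccc1`, differs from compound 1 by 3-cyanophenyl in place of 4-aminophenyl on a saturated chain carbon bound to an aromatic nitrogen. Among the measured compounds shown here, with no measured step to draw on, the expectation for this assay is no change beyond the scatter, and compound 4 is expected to stay at the limit. The estimate for compound 4 is 20000 nM, with a range from 5000 nM to 100000 nM, a step that the limit leaves unreadable from compound 1 to compound 4 being expected.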

Compound 4, half-maximal effective concentration: > 10000 nM
Compound 4: a limit, no number; the forecaster's own chance of this, stated with the estimate: 85%; the middle value is on the limit's open side.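

Compound 1 and compound 4 each give only a limit in this assay, not a number, and no step between them can be read: the limit of > 10000 nM in this assay, at which 2 of the 4 values shown sit.

The compounds shown leave open whether 3-cyanophenyl and 4-aminophenyl differ at all in this assay.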